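The source may report more compounds than this note shows. Statements on the series, on what has been measured and on what is new or still open speak of the compounds shown alone.

In a functional assay on CCRF-CEM cells (Homo sapiens) for inhibition, with a stated time of 3 days (a higher number here means a weaker inhibitor, a lower number a stronger inhibitor), compound 2 `Cc1c(C(=O)/C=C/c2ccc(Cl)cc2)[n+]([O-])c2ccccc2[n+]1[O-]` gives 16000 nM, and compound 1 `COc1ccc(/C=C/C(=O)c2c(C)[n+]([O-])c3ccccc3[n+]2[O-])cc1` gives 27600 nM. Compound 2 thus holds the lowest of the two numbers, though the step of a 1.7-fold lower number from compound 1 to compound 2 (0.24 log units; within the scatter) lies within the scatter, so the two compounds are not separated. Compound 3 `Cc1c(C(=O)/C=C/c2ccc(Cl)c(Cl)c2)[n+]([O-])c2ccccc2[n+]1[O-]` differs from compound 2 by chloro in place of hydrogen on an aromatic carbon. Within the data shown here, the only measured step, a 1.7-fold lower number from compound 1 to compound 2 (0.24 log units; within the scatter), exchanged one aromatic substituent for another and stayed within the scatter; it gives no guide to adding a second chloro, so no step beyond the scatter is expected. Compound 3 is estimated at 12000 nM, with a range from 5000 nM to 30000 nM. This estimate means an expected step of a 1.3-fold lower number from compound 2 to compound 3 (0.12 log units; within the scatter).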

Compound 3, half-maximal inhibitory concentration: 15400 nM
Beside the measured number, compound 3's estimate is 1.3-fold (0.11 log units) below it; low and high end bracket the measured number.
By their numbers in this assay, from the lowest: compounds 3, 2 and 1 (each within the scatter of the next).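

Placing a chloro ortho to the existing chloro, meta to a large group, gives a 1.0-fold lower number from compound 2 to compound 3 (0.02 log units; within the scatter) in this assay and so does not separate the two compounds. The full change from 4-methoxyphenyl to 3,4-dichlorophenyl gives a 1.8-fold lower number from compound 1 to compound 3 (0.25 log units; within the scatter) and likewise stays within the scatter, so all three compounds remain unseparated. No measurement offered here accounts for this flat result.

On these data alone, whether an amine or a carboxylic acid on this aromatic ring would move the number beyond the scatter remains open. So does the effect of a longer chain there.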